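Swapping the aryl amide in a serotonin-receptor series

This account rests on a few compounds, and the source may have more. Where it says the series, first, only, none or still open, it means among the compounds named here.

Two compounds share one core and differ only in the group on the amide carbonyl. Compound 1 `CCCCCCCC(=O)Nc1ccc2[nH]cc(C3CCN(C)CC3)c2n1` carries a heptyl chain and gives 32 nM in an assay for binding affinity to 5-hydroxytryptamine receptor 1B (Homo sapiens), read by radioligand binding; a lower number here means a stronger inhibitor, a higher number a weaker inhibitor. Compound 2 `CN1CCC(c2c[nH]c3ccc(NC(=O)c4ccc(C#N)cc4)nc23)CC1` carries a 4-cyanophenyl ring and gives 310 nM in this assay, the higher of the two numbers; the step of a 9.7-fold higher number from compound 1 to compound 2 (0.99 log units; beyond the scatter) shows the gap. Compound 3 `CN1CCC(c2c[nH]c3ccc(NC(=O)c4cccs4)nc23)CC1` is not yet measured; it differs from compound 2 by thiophen-2-yl in place of 4-cyanophenyl on a carbonyl carbon. For the measured compounds named here, the only measured step, from heptyl to 4-cyanophenyl, concerns a different exchange, so no step speaks directly to a thiophen-2-yl ring. Since both rings are aromatic, compound 3 is expected to land near compound 2, with a step of a 2.1-fold lower number from compound 2 to compound 3 (0.32 log units; beyond the scatter) in this assay that may fall within the scatter or be modest in either direction. The estimate for compound 3 is 150 nM, within 40 nM to 600 nM.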

Compound 3, inhibition constant: 390 nM
Estimate against measurement, compound 3: 2.6-fold (0.41 log units) below; low and high end bracket the measured number.
By their numbers in this assay, from the lowest: compound 1; then compounds 2 and 3 (each within the scatter of the next).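

In this assay, thiophen-2-yl in place of 4-cyanophenyl on the carbonyl carbon gives a 1.3-fold higher number from compound 2 to compound 3 (0.10 log units; within the scatter), so the two aromatic rings cannot be told apart here, even though one is a five-membered ring containing sulfur and the other a six-membered carbon ring carrying a nitrile. Replacing heptyl with thiophen-2-yl gives a 12-fold higher number from compound 1 to compound 3 (1.09 log units; beyond the scatter), so the gap first seen with 4-cyanophenyl now appears with a second, different aromatic ring. Nothing available gives a measured reason for either result.

On these data alone, whether this gap depends on the ring being aromatic or simply on losing the chain remains open, and a cyclohexyl ring on the carbonyl carbon would help separate the two. A shorter chain such as propyl would show how much the length of the heptyl chain matters.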